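The source may report more compounds than this note shows. Statements on the series, on what has been measured and on what is new or still open speak of the compounds shown alone.

Compound 1 `Cc1cn(C2CCN(Cc3cccc(Oc4ccccc4)n3)CC2)c(=O)[nH]c1=O`: > 64000 nM
Compound 2 `Cc1cn(C2CCN(Cc3cccc(Oc4ccc(F)c(F)c4)c3)CC2)c(=O)[nH]c1=O`: > 64000 nM

In an ADME assay on MRC5 cells (Homo sapiens) for cytotoxicity, read by fluorescence and resazurin assay, with a stated time of 3 days (a lower number here means a stronger inhibitor, a higher number a weaker inhibitor), compound 2 gives only a limit, > 64000 nM. Compound 1 also gives only a limit in this assay, > 64000 nM. Among the compounds with values here, both readings sit at the limit of > 64000 nM in this assay, at which 2 of the 2 values shown sit, so no step between them can be sized. Compound 3 `Cc1cn(C2CCN(Cc3cccc(Oc4cccc(OC(F)(F)F)c4)c3)CC2)c(=O)[nH]c1=O` is not yet measured; it differs from compound 2 by 3-(trifluoromethoxy)phenyl in place of 3,4-difluorophenyl on an oxygen on an aromatic ring. Within the data shown here, with no measured step to rest on, no step beyond the scatter is expected, and compound 3 is expected to stay at the limit. Its value is estimated at 70000 nM, from 30000 nM to 150000 nM. The expected step is a step that the limit leaves unreadable from compound 2 to compound 3.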

Compound 3, half-maximal inhibitory concentration: 5260 nM
The estimate for compound 3 lay 13-fold (1.12 log units) above the measured number, outside the stated range (below it).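

In this assay, the group on this oxygen clearly matters: 3-(trifluoromethoxy)phenyl in place of 3,4-difluorophenyl gives an at least 12-fold lower number from compound 2 to compound 3 (1.08 log units; beyond the scatter). Compound 3 is the only compound shown that gives a number and not a limit, so a change at this place alone can bring the reading into the measurable range. The full size of the step stays unknown because compound 2 gives only a limit: the limit of > 64000 nM in this assay, at which 2 of the 3 values shown sit.

The compounds shown do not separate the arrival of trifluoromethoxy from the loss of the fluorines. From the compounds shown here alone, how a methoxy group or a carboxylic acid on this ring would read remains open.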